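Chloro for Fluoro: Cytotoxicity Outlook for Compound 3

The source may hold more compounds than are shown below. What is called first, only, known or untested is meant among the compounds shown, and "the series" means these compounds.

Compound 2 `CNC(=O)c1c(NO)cc(-c2ccc(F)cc2)oc1=O` was examined in an ADME assay on Huh-7 cells (Homo sapiens) for cytotoxicity, read by a luciferase reporter and WST assay, with a stated time of 3 days; a lower number here means that less compound is tolerated, a higher number that more compound is tolerated. In this assay compound 2 returns only a limit, > 20000 nM, and not a number. Compound 1 `Cc1ccc(NC(=O)c2c(NO)cc(-c3ccc(Cl)cc3)oc2=O)cc1` likewise returns a limit, > 20000 nM. Both readings sit at the limit of > 20000 nM in this assay, at which 2 of the 2 values shown sit, so compound 2 stands at the ceiling of what this assay reports, and nothing shown sets it apart from compound 1. Within the data shown here, no two measured compounds differ in a single place, so no measured step is available.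

Compound 3 `CNC(=O)c1c(NO)cc(-c2ccc(Cl)cc2)oc1=O` differs from compound 2 by chloro in place of fluoro on an aromatic carbon. The expected step, a number no higher from compound 2 to compound 3 (the limit leaves the size open), is none beyond the scatter in this assay, because compound 1 also carries chloro and reports > 20000 nM. Compound 3 is therefore estimated at 20000 nM, with a range of 10000 nM to 40000 nM, most likely again as a limit.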

Compound 3, half-maximal cytotoxic concentration: > 20000 nM
Compound 3: a limit, no number; the forecaster's own chance of this, stated with the estimate: 80%; the middle value lies on the limit itself.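

No step from compound 1 or compound 2 to compound 3 can be read in this assay, since all three rest on the same limit: the limit of > 20000 nM in this assay, at which 3 of the 3 values shown sit.

The compounds shown leave open how much of each is actually tolerated, and whether chloro and fluoro differ at all in this respect.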